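A few compounds are considered here, and "the series" means these few. Any claim that something is new, unique, unknown or untested is made for them only; others in the source may bear on it.

Measured so far in a functional assay on A549 cells (Homo sapiens) for cytotoxicity, read by MTT assay, with a stated time of 48 h; on this read-out lower numbers stand for stronger inhibition and higher numbers for weaker inhibition:
- Compound 1 `C=C1C(=O)O[C@H]2CC3=C[C@H](C/C(C)=C/[C@@H](OC(=O)/C=C/c4ccc(N(C)C)cc4)[C@H]12)OC3=O`: > 10000 nM (a limit of the assay, not a number)
- Compound 2 `C=C1C(=O)O[C@H]2CC3=C[C@H](C/C(C)=C/[C@@H](OC(=O)CC4CCCCC4)[C@H]12)OC3=O`: 6900 nM

Among the compounds with values here, compound 2 holds the only true number, so there is no spread of values against which to rank it. The other result is the limit of > 10000 nM in this assay, at which 1 of the 2 values shown sits.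

The next compound is compound 3 `C=C1C(=O)O[C@H]2CC3=C[C@H](C/C(C)=C/[C@@H](OC(=O)C(C)(C)CC)[C@H]12)OC3=O`, which has 1,1-dimethylpropyl in place of cyclohexylmethyl on a carbonyl carbon. The shared core stays unchanged.

Within the data shown here, only one measured step bears on this change, as it falls on the same carbonyl carbon: an at least 1.4-fold lower number from compound 1 to compound 2 (0.16 log units; that floor lies within the scatter). That step is a floor rather than a size, and it involves a different departing group, so it gives no direction for the new change. With nothing else to go on, no shift beyond the scatter is expected in this assay. Among the measured compounds shown here, the expected change is a 1.2-fold higher number from compound 2 to compound 3 (0.06 log units; within the scatter), which is no real step. A report of compound 3 as a limit would not be surprising.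

For compound 3 the estimated value is 8000 nM, with an expected range of 3500 nM to 18000 nM.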

Compound 3, half-maximal inhibitory concentration: 2200 nM
The estimate for compound 3 lay 3.6-fold (0.56 log units) above the measured number; the measured number lies below the stated range.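

In this assay, the group on this carbonyl carbon now makes a difference beyond the scatter: 1,1-dimethylpropyl in place of cyclohexylmethyl gives a 3.1-fold lower number from compound 2 to compound 3 (0.50 log units; beyond the scatter), whereas the earlier step at this place was only a floor within the scatter. Replacing 2-(4-(dimethylamino)phenyl)ethenyl with 1,1-dimethylpropyl gives an at least 4.5-fold lower number from compound 1 to compound 3 (0.65 log units; beyond the scatter), and the size of that step is a floor, not a measured distance. Compound 1 stands as a limit of the assay, not a number: the limit of > 10000 nM in this assay, at which 1 of the 3 values shown sits.

The step from compound 2 to compound 3 removes the six-membered ring, lowers the heavy-atom count and changes the branching at the first carbon of the chain all at once, so this single pair cannot say which of these changes goes with the lower number. A straight pentyl chain or a cyclohexyl group on the same carbonyl carbon would help separate these changes, and a chain carrying an amine or a carboxylic acid would show how far the position tolerates groups other than plain carbon.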